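The source may hold more compounds than are shown below. What is called first, only, known or untested is meant among the compounds shown, and "the series" means these compounds.

Measured compounds in a functional assay on MCF7 cells (Homo sapiens) for antiproliferative activity, read by MTT assay, with a stated time of 48 h; on this read-out higher numbers stand for weaker inhibition and lower numbers for stronger inhibition:
Compound 1 `N#CC1=C(N)Oc2c(c3nc4ccccc4nc3c3ccccc23)C12C(=O)N(Cc1cnnn1-c1ccc(F)cc1)c1ccccc12`: the read-out for compound 1 is a limit of the assay, > 50000 nM.
Compound 2 `CCOc1ccc(-n2nncc2CN2C(=O)C3(C(C#N)=C(N)Oc4c3c3nc5ccccc5nc3c3ccccc43)c3ccccc32)cc1`: the read-out for compound 2 is likewise a limit of the assay, > 50000 nM.

Among the measured compounds shown here, compound 1 therefore stands at a limit and not at a number, and the one further value shown sits at the same limit, so no number places compound 1 on a scale of potency. For the measured compounds named here, the single measured step, a step that the two limits leave unreadable from compound 1 to compound 2, cannot be sized, since (the limit of > 50000 nM in this assay, at which 2 of the 2 values shown sit).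

Compound 3 `Cc1ccc(Cl)cc1-n1nncc1CN1C(=O)C2(C(C#N)=C(N)Oc3c2c2nc4ccccc4nc2c2ccccc32)c2ccccc21` differs from compound 1 in the group carried on the ring nitrogen: 5-chloro-2-methylphenyl in place of 4-fluorophenyl on an aromatic nitrogen. Going by the values given here, no measured step bears directly on this exchange; the one step known lies between two limits and gives no readable size in either direction. Compound 3 is accordingly expected to show no readable step, a step that the limit leaves unreadable from compound 1 to compound 3, with the assay most likely again returning only a limit. Compound 3 is estimated at 60000 nM, in a range from 20000 nM to 200000 nM.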

Compound 3, half-maximal inhibitory concentration: > 50000 nM
Compound 3: no number, only a limit; the forecaster's own chance of this, stated with the estimate: 85%; the middle value does not contradict the limit.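

In this assay compound 3 gives > 50000 nM, which is a limit of the assay and not a number. No step can be read between compound 3 and either compound 1 or compound 2, since all three stand at the same limit: the limit of > 50000 nM in this assay, at which 3 of the 3 values shown sit.

The compounds shown leave open whether the group on the aromatic nitrogen changes the read-out in this assay at all.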